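A few compounds are considered here, and "the series" means these few. Any claim that something is new, unique, unknown or untested is made for them only; others in the source may bear on it.

Compound 1 `COc1ccc(C2SCC(=O)N2CCN2CCCCC2)cc1` gives 33% in an ADME assay on Vero cells (Chlorocebus sabaeus) for cytotoxicity, read by neutral red uptake, tested at 787 ug/mL; on this read-out higher numbers stand for a weaker effect at the one concentration tested and lower numbers for a stronger effect; compound 2 `O=C1CSC(c2cccc(O)c2)N1CCN1CCCCC1` gives 60%.

Of the two numbers in this assay, compound 2 stands highest, with compound 1 as its nearest neighbour and the gap between them beyond the scatter. Compound 3 `O=C1CSC(c2ccc(O)cc2)N1CCN1CCCCC1` differs from compound 2 in one place: 4-hydroxyphenyl in place of 3-hydroxyphenyl on a saturated ring carbon. Among the measured compounds shown here, no measured pair isolates this change, so the expectation rests on compounds 1 and 2 alone. In this assay the step is expected to be small and downward, about a number 10 percentage points lower from compound 2 to compound 3 (within the scatter), close to the edge of the scatter. Compound 3 is therefore estimated at 50%, within a range from 25% to 75%.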

Compound 3, a percentage reported as activity, at one concentration (the size of the read-out at that concentration, not a potency): 57%
For compound 3 the middle estimate is 7 percentage points below the measured one; the measured number falls inside the stated range.
By their numbers in this assay, from the lowest: compound 1; then compounds 3 and 2 (each within the scatter of the next).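

Placed on the saturated ring carbon, 4-hydroxyphenyl in place of 3-hydroxyphenyl gives a number 3 percentage points lower from compound 2 to compound 3 (within the scatter) in this assay and leaves the two hydroxyphenyl groups indistinguishable on this read-out. Hydrogen in place of methyl on the oxygen on the aromatic ring gives a number 24 percentage points higher from compound 1 to compound 3 (beyond the scatter) and is thus the single change here that separates two compounds beyond the scatter. No measurement offered here explains either step.

Going by these compounds, whether an amine or a carboxylic acid in place of the hydroxyl would shift the number beyond the scatter remains open.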